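Second trifluoromethyl on the ether ring: a repeated change

The source may hold more compounds than are shown below. What is called first, only, known or untested is meant among the compounds shown, and "the series" means these compounds.

Measured compounds in a functional assay on VCaP cells (Homo sapiens) for antiproliferative activity, read by propidium iodide staining, with a stated time of 96 h; on this read-out lower numbers stand for stronger inhibition and higher numbers for weaker inhibition:
Compound 1, `CC(O)(COc1cccc(C(F)(F)F)c1)C(=O)Nc1ccc(S(F)(F)(F)(F)F)cc1`: 24700 nM
Compound 2, `CC(O)(COc1cc(C(F)(F)F)cc(C(F)(F)F)c1)C(=O)Nc1ccc(S(F)(F)(F)(F)F)cc1`: 2600 nM
Compound 3, `CC(O)(COc1cccc(C(F)(F)F)c1)C(=O)Nc1cccc(S(F)(F)(F)(F)F)c1`: 22500 nM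

Compound 1 and compound 3 share the same atoms, joined differently; the difference between the two cores is not broken down here. Their values sit close together, within the scatter of each other. From compound 1 to compound 2 the change is trifluoromethyl in place of hydrogen on an aromatic carbon, and it gave a 9.5-fold lower number from compound 1 to compound 2 (0.98 log units; beyond the scatter) in this assay.

Compound 4, `CC(O)(COc1cc(C(F)(F)F)cc(C(F)(F)F)c1)C(=O)Nc1cccc(S(F)(F)(F)(F)F)c1`, is not yet measured. It differs from compound 3 by trifluoromethyl in place of hydrogen on an aromatic carbon, the same change as from compound 1 to compound 2, at the same kind of place. Because compound 1 to compound 2 gave a 9.5-fold lower number from compound 1 to compound 2 (0.98 log units; beyond the scatter), a step of similar size is expected here, namely an 8.7-fold lower number from compound 3 to compound 4 (0.94 log units; beyond the scatter). The estimate for compound 4 is therefore 2600 nM, expected to lie between 1200 nM and 6000 nM.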

Compound 4, half-maximal inhibitory concentration: 2800 nM
Beside the measured number, compound 4's estimate is 1.1-fold (0.03 log units) below it; the range from low to high includes it.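

In this assay, trifluoromethyl in place of hydrogen on an aromatic carbon gave an 8.0-fold lower number from compound 3 to compound 4 (0.91 log units; beyond the scatter). The change carried from one core to the other with a step of similar size: the same change on two cores in this assay, a 9.5-fold lower number (0.98 log units; beyond the scatter) from compound 1 to compound 2 and an 8.0-fold lower number (0.91 log units; beyond the scatter) from compound 3 to compound 4, 1.2-fold (0.07 log units) apart, within the scatter of two such steps. This shows that the step held on these two cores, but it does not show that it would hold on any other core or at any other place on the ring, and it does not explain why the number falls.

The compounds shown leave open whether a nitrile or a chlorine atom in place of the added trifluoromethyl would give a step of similar size. They also leave open whether the step would persist with an amine in place of the hydroxyl group.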